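Replacing the oxime-type group with a nitrile on the pyrrole

A few compounds are considered here, and "the series" means these few. Any claim that something is new, unique, unknown or untested is made for them only; others in the source may bear on it.

Measured compounds:
compound 1, `Cc1c(C=O)cc(-c2ccc(S(C)(=O)=O)cc2)n1-c1cccc(F)c1`, "not determined" (no result reported);
compound 2, `Cc1c(/C=N\O)cc(-c2ccc(S(C)(=O)=O)cc2)n1-c1cccc(F)c1`, 45%.

Compound 1 has the structure `Cc1c(C=O)cc(-c2ccc(S(C)(=O)=O)cc2)n1-c1cccc(F)c1` and in a functional assay on the whole organism (strain Swiss albino) for inhibition, with Mus musculus as the target, in the writhing test, with a stated time of 30 min, at a dose of 40 mg/kg by the oral route (a higher number here means a stronger effect of the compound at the dose given, a lower number a weaker effect), compound 1 gives "not determined" (no result reported), so no number for it was reported. Compound 2, `Cc1c(/C=N\O)cc(-c2ccc(S(C)(=O)=O)cc2)n1-c1cccc(F)c1`, gives 45% in this assay. On the numbers shown, compound 2 is the only compound with a value, so it cannot be placed against any other.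

Compound 3, `Cc1c(C#N)cc(-c2ccc(S(C)(=O)=O)cc2)n1-c1cccc(F)c1`, has not been measured. Compared with compound 2 the change is a group of 2 heavy atoms (1 carbon, 1 nitrogen; no ring) in place of a group of 3 heavy atoms (1 carbon, 1 nitrogen, 1 oxygen; no ring), on an aromatic carbon. The group that leaves and the cyano group that enters sit on the same aromatic carbon of the shared core.

Within the data shown here, no step between measured compounds is available to calibrate this change. My expectation is therefore a step within the usual scatter, perhaps tending slightly downward, with the estimated change being a number 5 percentage points lower from compound 2 to compound 3 (within the scatter). Compound 3 is estimated to give 40% in this assay, within a range from 15% to 65%.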

Compound 3, a percentage reported as inhibition, in the whole organism at one dose (the size of the read-out at that dose, not a potency): 38%
Compound 3: the middle estimate sits 2 percentage points above what was measured, and the stated range covers the measured number.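

Among these compounds, the step from the oxime-type group to cyano gives the first comparison at this position: in this assay, the change is a number 7 percentage points lower from compound 2 to compound 3 (within the scatter). On this aromatic carbon, then, a cyano group with no hydrogen-bond donor can stand in place of a larger group that carries one, and the read-out stays within the usual scatter, though this is one step at a single dose and not a measure of potency. Nothing shown explains this result, and no data bear on why the two groups fall so close together.

On these data alone, it remains open whether a carboxylic acid, an amide or an aminomethyl group on the same carbon would move the read-out beyond the scatter. Also open, as far as these compounds go, is whether the swap to cyano would give a similar step if the 3-fluorophenyl group were replaced by another group.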